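Chloro in place of methyl on the shared core

The compounds below may be only part of what the source reports. "The series", "measured", "known", "first", "only" and "open" are said of these compounds alone.

Measured compounds in a functional assay on CHO cells for antagonist activity at transient receptor potential cation channel subfamily V member 1 (Rattus norvegicus), read by calcium flux; on this read-out lower numbers stand for stronger inhibition and higher numbers for weaker inhibition:
compound 1 `Fc1cc(-c2nc(N3CCN(c4ncccc4C(F)(F)F)CC3)[nH]c2-c2ccc(C(F)(F)F)cc2)cc(F)c1F`: 7 nM
compound 2 `Fc1cc(F)cc(-c2nc(N3CCN(c4ncccc4C(F)(F)F)CC3)[nH]c2-c2ccc(C(F)(F)F)cc2)c1`: 35 nM
compound 3 `Cc1nc(N2CCN(c3ncccc3C(F)(F)F)CC2)[nH]c1-c1ccc(C(F)(F)F)cc1`: 628 nM

Compound 3 stands highest of the three numbers; the nearest is compound 2, separated by an 18-fold higher number from compound 2 to compound 3 (1.25 log units; beyond the scatter), and the furthest is compound 1, separated by a 90-fold higher number from compound 1 to compound 3 (1.95 log units; beyond the scatter). Both of these steps exchange a fluorinated phenyl for methyl on the same aromatic carbon, and both are large. Within the phenyl pair the change is smaller: a 5.0-fold higher number from compound 1 to compound 2 (0.70 log units; beyond the scatter).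

Compound 4 `FC(F)(F)c1ccc(-c2[nH]c(N3CCN(c4ncccc4C(F)(F)F)CC3)nc2Cl)cc1` differs from compound 3 by chloro in place of methyl on an aromatic carbon. Among the measured compounds shown here, no measured step swaps one small group for another at this carbon; the two large steps show that the carbon is sensitive, but they compare methyl against a substituted phenyl, not against chloro, so they bound the possible size rather than fix the direction. A small step is therefore expected, a 1.3-fold lower number from compound 3 to compound 4 (0.10 log units; within the scatter), not clearly beyond the scatter. Compound 4 is estimated at 500 nM, with a range from 150 nM to 1800 nM.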

Compound 4, half-maximal inhibitory concentration: 160 nM
Compound 4: the middle estimate sits 3.1-fold (0.49 log units) above what was measured; measured number inside the range.
By their numbers in this assay, from the lowest: compound 1; then compound 2; then compound 4; then compound 3.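

In this assay an exchange of one small group for another at this aromatic carbon now has a measured size, a 3.9-fold lower number from compound 3 to compound 4 (0.59 log units; beyond the scatter) and so chloro and methyl are not interchangeable here. Measured from chloro rather than methyl, the steps to the fluorinated phenyl compounds shrink: a 4.6-fold higher number from compound 2 to compound 4 (0.66 log units; beyond the scatter) is modest, and only a 23-fold higher number from compound 1 to compound 4 (1.36 log units; beyond the scatter) stays large, so part of the apparent gain from a phenyl group at this carbon was the poorer baseline set by methyl.

From the compounds shown here alone, whether bromo, a nitrile or an ethyl group at this carbon would carry the trend past chloro remains open, as does how unsubstituted phenyl would compare with chloro. Nothing measured here explains the difference between chloro and methyl.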